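Swapping fluorines and a methyl on the benzyl ring

This account rests on a few compounds, and the source may have more. Where it says the series, first, only, none or still open, it means among the compounds named here.

Three compounds share one core and differ only in the group carried on the saturated chain carbon bound to an amine nitrogen in a ring. Compound 1 `Cc1cccc(CN2Cc3c(NC(=O)c4ccccc4)n[nH]c3C2(C)C)c1`, compound 2 `CC1(C)c2[nH]nc(NC(=O)c3ccccc3)c2CN1Cc1cccc(I)c1` and compound 3 `CC1(C)c2[nH]nc(NC(=O)c3ccccc3)c2CN1Cc1cccc(F)c1F` were tested in an assay on Sf21 cells for inhibition of high affinity nerve growth factor receptor (Homo sapiens), read by HTRF, with a stated time of 30 min, in the presence of a further agent that is not named here; a higher number here means a weaker inhibitor, a lower number a stronger inhibitor. There compound 1 gives 1100 nM, compound 2 gives 1360 nM and compound 3 gives 200 nM, the lowest of the three numbers. The step of a 5.5-fold lower number from compound 1 to compound 3 (0.74 log units; beyond the scatter) and the step of a 6.8-fold lower number from compound 2 to compound 3 (0.83 log units; beyond the scatter) both reach beyond the scatter, whereas a 1.2-fold higher number from compound 1 to compound 2 (0.09 log units; within the scatter) does not.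

Compound 4 `Cc1ccc(F)c(CN2Cc3c(NC(=O)c4ccccc4)n[nH]c3C2(C)C)c1` is not yet measured. Its difference from compound 3 is 2-fluoro-5-methylphenyl in place of 2,3-difluorophenyl on a saturated chain carbon bound to an amine nitrogen in a ring. One fluorine of compound 3 stays in place, the other is removed, and a methyl is added elsewhere on the ring. The measured steps show that a single methyl or iodo substituent, as in compound 1 and compound 2, runs well weaker than the two fluorines of compound 3, and compound 4 sits between those patterns. A modest loss in this assay is therefore expected, as the step of a 2.0-fold higher number from compound 3 to compound 4 (0.30 log units; within the scatter). For compound 4 the expected value is 400 nM, with a likely range from 130 nM to 1200 nM.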

Compound 4, half-maximal inhibitory concentration: 880 nM
Compound 4: the middle estimate sits 2.2-fold (0.34 log units) below what was measured, within the range that was stated.
By their numbers in this assay, from the lowest: compound 3; then compounds 4, 1 and 2 (each within the scatter of the next).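

The result shows that one fluorine on the benzyl ring does not by itself carry the strength of compound 3. In this assay, keeping one fluorine while swapping the 2,3-difluorophenyl for 2-fluoro-5-methylphenyl gives a 4.4-fold higher number from compound 3 to compound 4 (0.64 log units; beyond the scatter), so most of the advantage seen with compound 3 is gone in this pair. Compound 4 also cannot be told apart from the methyl and iodo compounds, with a 1.3-fold lower number from compound 1 to compound 4 (0.10 log units; within the scatter), showing that adding the fluorine to the methyl-bearing ring changes nothing measurable here, and a 1.5-fold lower number from compound 2 to compound 4 (0.19 log units; within the scatter), so this position tolerated three different patterns with no separation while only the 2,3-difluorophenyl stands clear; nothing available here explains this difference.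

Compound 4 differs from compound 3 by both a lost fluorine and an added methyl, so these compounds cannot say which of the two changes accounts for the loss. Also open, as far as these compounds go, is how an unsubstituted phenyl, or a ring carrying two chlorines or a methoxy group, would compare on the same core.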